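Fluorine on the fused ring of a quinoline amide

This account rests on a few compounds, and the source may have more. Where it says the series, first, only, none or still open, it means among the compounds named here.

Compound 1 `COc1cc2c(Oc3ccc(NC(=O)c4cc(-c5ccccc5)nc5ccccc45)cc3F)ccnc2cc1OCCCN1CCCCC1` is the weaker of the two measured compounds: in a functional assay on U-87MG ATCC cells (Homo sapiens) for cytotoxicity, read by MTT assay, with a stated time of 72 h (on this read-out lower numbers stand for stronger inhibition and higher numbers for weaker inhibition), compound 1 gives 1490 nM, while compound 2 `COc1cc2c(Oc3ccc(NC(=O)c4cc(-c5cccc(Cl)c5)nc5ccccc45)cc3F)ccnc2cc1OCCCN1CCCCC1` gives 150 nM. Among the compounds with values here, the only measured step is a 9.9-fold lower number from compound 1 to compound 2 (1.00 log units; beyond the scatter). That step concerns a chloro elsewhere in the molecule. Compound 3 `COc1cc2c(Oc3ccc(NC(=O)c4cc(-c5ccccc5)nc5ccc(F)cc45)cc3F)ccnc2cc1OCCCN1CCCCC1` differs from compound 1 by fluoro in place of hydrogen on an aromatic carbon. Within the data shown here, since the sole reference step concerns a different part of the structure, only a small change is expected, a 1.7-fold lower number from compound 1 to compound 3 (0.22 log units; within the scatter), likely toward a somewhat lower number. Compound 3 is therefore estimated at 900 nM, within 300 nM to 3000 nM.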

Compound 3, half-maximal inhibitory concentration: 690 nM
Compound 3: the middle estimate sits 1.3-fold (0.12 log units) above what was measured, within the range that was stated.
By their numbers in this assay, from the lowest: compound 2; then compound 3; then compound 1.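

In this assay, fluoro in place of hydrogen on this aromatic carbon of the fused rings gives a 2.2-fold lower number from compound 1 to compound 3 (0.33 log units; beyond the scatter) and this modest step lies just beyond the usual scatter. The number can therefore shift with one added fluorine here, and not only with the chloro on the other ring of compound 2. Nothing available explains the drop.

On these data alone, it remains open whether a nitrile or an amine on this same carbon would lower the number further or raise it. Also open, as far as these compounds go, is whether fluoro here and the chloro of compound 2 would combine in a single molecule.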